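The source may hold more compounds than are shown below. What is called first, only, known or untested is meant among the compounds shown, and "the series" means these compounds.

Measured compounds:
compound 1 `CC(=O)OC/C1=C/C[C@](C)(CCC=C(C)C)/C=C/[C@@H](OC(=O)C=C(C)C)[C@](C)(OC(C)=O)/C=C/C1=O`, 4130 nM
compound 2 `CC(C)=CCC[C@]1(C)/C=C/[C@@H](OC(=O)C=C(C)C)[C@](C)(O)/C=C/C(=O)/C(CCl)=C\C1`, 840 nM

The account follows two macrocycles tested in a functional assay on SMMC-7721 cells (Homo sapiens) for antiproliferative activity, read by MTT assay, with a stated time of 48 h; a higher number here means a weaker inhibitor, a lower number a stronger inhibitor. Compound 1, whose structure is shown at the start of this part, gives 4130 nM in this assay. Compound 2 gives 840 nM in this assay, the lowest of the two numbers at hand; the number for compound 1 is higher, and the gap between the two lies beyond the usual scatter. Beyond these two values nothing is known about how changes on the shared core move the read-out.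

Compound 3 `CC(C)=CCC[C@]1(C)/C=C/[C@@H](OC(=O)C=C(C)C)[C@](C)(O)/C=C/C(=O)/C(C(=O)N(C(C)C)C(C)C)=C\C1` has not been measured. It differs from compound 2 in one place: diisopropylcarbamoyl in place of chloromethyl on a double-bonded ring carbon. Going by the values given here, no step between measured compounds involves this position, so there is no direct precedent for what the exchange does. With only the two values in hand, compound 3 is expected to give a higher number than compound 2, a step of a 3.6-fold higher number from compound 2 to compound 3 (0.55 log units; beyond the scatter), beyond the scatter but not large. On that basis compound 3 is estimated at 3000 nM in this assay, with a range from 800 nM to 12000 nM.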

Compound 3, half-maximal inhibitory concentration: 17200 nM
Estimate against measurement, compound 3: 5.7-fold (0.76 log units) below; the measured number lies above the stated range.
By their numbers in this assay, from the lowest: compound 2; then compound 1; then compound 3.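

In this assay, going by these compounds alone, placing diisopropylcarbamoyl where chloromethyl stood on the double-bonded ring carbon gives a 20-fold higher number from compound 2 to compound 3 (1.31 log units; beyond the scatter) as a large step, and this is the first step read at this position. It shows that the read-out is not indifferent to what this ring carbon carries: with the rest of the molecule unchanged, including the hydroxy group and the ((2-methylprop-1-en-1-yl)carbonyl)oxy group, this single exchange is enough to move the number well beyond the scatter. No measurement at hand speaks to why the number rises with this exchange.

A single exchange does not tell whether the step follows from losing chloromethyl, from gaining the carbamoyl unit or from the two isopropyl groups on its nitrogen, since both groups change at once. It also leaves open where a plain methyl, a hydroxymethyl, a bromomethyl, a primary carboxamide, a dimethylcarbamoyl or a carboxylic acid on the same ring carbon would fall relative to compound 2 and compound 3.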